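A few compounds are considered here, and "the series" means these few. Any claim that something is new, unique, unknown or untested is made for them only; others in the source may bear on it.

Compound 1 `CCOC(=O)C1=Cc2ccccc2OC1(OCc1cn(CC(=O)Nc2cccc(Cl)c2)nn1)C(F)(F)F`: in a functional assay on DU-145 cells (Homo sapiens) for inhibition, read by MTT assay, with a stated time of 24 h (on this read-out higher numbers stand for weaker inhibition and lower numbers for stronger inhibition), compound 1 gives 10100 nM.
Compound 2 `CCOC(=O)C1=Cc2ccccc2OC1(OCc1cn(-c2ccc([N+](=O)[O-])cc2)nn1)C(F)(F)F`: compound 2 gives > 150000 nM, a limit of the assay rather than a number.

Compound 2 thus sits at the limit of > 150000 nM in this assay, at which 1 of the 2 values shown sits, so only a boundary is known for it. Compound 3 `CCOC(=O)C1=Cc2ccccc2OC1(OCc1cn(-c2ccc(C)cc2)nn1)C(F)(F)F` differs from compound 2 by methyl in place of nitro on an aromatic carbon. Within the data shown here, the only measured step, an at least 14-fold higher number from compound 1 to compound 2 (1.17 log units; beyond the scatter), exchanged the whole group on the aromatic nitrogen, not a substituent on the phenyl ring, so it offers no direct guide here. Compound 3 is expected to give about 100000 nM, somewhere between 20000 nM and 300000 nM. The implied step, an at least 1.5-fold lower number from compound 2 to compound 3 (0.17 log units; that floor lies within the scatter), is expected to be no more than a loose guess, and a limit is quite possible.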

Compound 3, half-maximal inhibitory concentration: 30200 nM
The estimate for compound 3 lay 3.3-fold (0.52 log units) above the measured number; the measured number falls inside the stated range.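

In this assay, methyl in place of nitro on the aromatic carbon para to a large group gives an at least 4.9-fold lower number from compound 2 to compound 3 (0.69 log units; beyond the scatter), so a change on the phenyl ring alone can move this read-out. The value for compound 2 is a limit, which leaves the true size of that step unknown: the limit of > 150000 nM in this assay, at which 1 of the 3 values shown sits.

With nitro gone, 4-methylphenyl in place of ((3-chlorophenyl)carbamoyl)methyl on the aromatic nitrogen still gives a 3.0-fold higher number from compound 1 to compound 3 (0.48 log units; beyond the scatter), so part of the earlier loss remains. Open, on these data alone, is how an amine or a methoxy group would read at this same place on the ring, and whether methyl differs from plain hydrogen there.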